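A few compounds are considered here, and "the series" means these few. Any claim that something is new, unique, unknown or untested is made for them only; others in the source may bear on it.

Three close relatives share one core, and only one of them has returned a number. In a functional assay on A-375 cells (Homo sapiens) for antiproliferative activity, read by trypan blue exclusion, with a stated time of 48 h, tested at 1 uM (on this read-out higher numbers stand for a weaker effect at the one concentration tested and lower numbers for a stronger effect), compound 3 `CC(=O)Nc1nc(-c2cccc(NS(=O)(=O)c3ccc(C#CCO)cc3)c2)cs1` gives 81.3%, a fairly weak effect at the single concentration tested. Compound 1 `CC(=O)Nc1nc(-c2cccc(NS(=O)(=O)c3ccc(Br)cc3)c2)cs1` was reported as "not active" (no number reported). Compound 2 `CC(=O)Nc1nc(-c2cccc(NS(=O)(=O)c3cccc(Br)c3)c2)cs1` was likewise reported as "not active" (no number reported). So compound 3 stands as the only entry with a measured figure, and the two bromine-bearing relatives gave nothing to compare against.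

Compound 4 `C#Cc1ccc(S(=O)(=O)Nc2cccc(-c3csc(NC(C)=O)n3)c2)cc1` is the next step: hydrogen in place of hydroxymethyl on a triple-bonded carbon. The 3-hydroxyprop-1-yn-1-yl group of compound 3 becomes a bare ethynyl group. Going by the values given here, no pair of measured compounds spans a comparable change, so the size of the step can only be guessed. The loss of the hydroxymethyl portion brings compound 4 nearer in overall shape to the inactive pair, which points towards a weaker effect or, at best, a difference lost in the scatter. The step from compound 3 to compound 4 is expected to be a number 6.7 percentage points higher from compound 3 to compound 4 (within the scatter). Compound 4 is therefore expected to give about 88%, with a range from 72% to 100%.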

Compound 4, a percentage reported as activity, at one concentration (the size of the read-out at that concentration, not a potency): 59.2%
For compound 4 the middle estimate is 28.8 percentage points above the measured one; measured number below the stated range.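

Trimming 3-hydroxyprop-1-yn-1-yl to ethynyl gives a number 22.1 percentage points lower from compound 3 to compound 4 (beyond the scatter) in this assay and, on this read-out, that means a stronger effect at the one concentration tested. Going by these compounds alone, this is the first measured sign that the group on the triple-bonded carbon can change the result, and it shows that hydroxymethyl at this place is not needed for the effect. Nothing available explains why the effect changes with this step.

It remains open whether the triple bond itself matters, since no compound shown separates its contribution from that of the end group. From the compounds shown here alone, how a methyl group, an amine or a carboxylic acid on the triple-bonded carbon would compare with hydrogen also remains unknown, as does the behaviour of a longer chain there.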